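The source may hold more compounds than are shown below. What is called first, only, known or untested is meant among the compounds shown, and "the series" means these compounds.

The account concerns two measured compounds and one that awaits measurement. Compound 1 `Cc1n[nH]c(C(=O)O)c1Cc1cccc(-c2cccc(F)c2)c1` and compound 2 `CCc1n[nH]c(C(=O)O)c1Cc1cccc(-c2ccc(F)cc2)c1` share a core and differ in two places at once. In an assay on isolated protein for inhibition of 2-Hydroxyacid oxidase 2 (Rattus norvegicus) (a higher number here means a weaker inhibitor, a lower number a stronger inhibitor), compound 1 gives 500 nM, and in this assay compound 2 gives 300 nM; the two numbers lie within the usual scatter of one another, so neither stands apart from the other.

The step followed here leads from compound 1 to compound 3 `Cc1n[nH]c(C(=O)O)c1Cc1cccc(OC(F)(F)F)c1`. The change is trifluoromethoxy in place of 3-fluorophenyl on an aromatic carbon. Among the measured compounds shown here, no pair of measured compounds covers a change of this kind, so there is no measured step to lean on. The writer expects the number to move upward, that is toward weaker inhibition, by a step of roughly a 6.0-fold higher number from compound 1 to compound 3 (0.78 log units; beyond the scatter), more than the scatter would account for. Compound 3 is therefore estimated at 3000 nM, with a range from 800 nM to 12000 nM.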

Compound 3, half-maximal inhibitory concentration: 700 nM
Estimate against measurement, compound 3: 4.3-fold (0.63 log units) above; measured number below the stated range.
By their numbers in this assay, from the lowest: compounds 2, 1 and 3 (each within the scatter of the next, the first and the last beyond it).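

Trifluoromethoxy takes the place of 3-fluorophenyl on an aromatic carbon in a step of a 1.4-fold higher number from compound 1 to compound 3 (0.15 log units; within the scatter) in this assay, so this exchange moves the number no further than the scatter. For this pair, then, a group with no ring at this position reads the same as one carrying a six-membered aromatic ring, which the two earlier compounds, differing in two places at once, could not show. Nothing available explains why these two groups read alike.

On these data alone, whether an amine, a carboxylic acid or a simple methoxy group at this position would also stay within the scatter of compound 1 remains open. So does whether trifluoromethoxy would behave in the same way on the core of compound 2, with its ethyl group.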